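The source may report more compounds than this note shows. Statements on the series, on what has been measured and on what is new or still open speak of the compounds shown alone.

Compound 1 `COc1c(N2CC[C@@H](CO)C2)c(F)cc2c(=O)c(C(=O)O)cn(Cc3ccc(-c4ccccc4)cc3)c12` gives > 200000 nM in an assay on isolated protein for inhibition of DNA topoisomerase 1 (Homo sapiens), with a stated time of 15 min (a lower number here means a stronger inhibitor, a higher number a weaker inhibitor), which is a limit of the assay rather than a number. Compound 2 `CNCCNc1cc2c(cc1F)c(=O)c(C(=O)O)cn2Cc1ccc(-c2ccccc2)cc1` gives > 200000 nM in this assay, again a limit. Compound 3 `CNCCCNc1c(F)cc2c(=O)c(C(=O)O)cn(Cc3ccc(-c4ccccc4)cc3)c2c1OC` gives 101000 nM in this assay.

Within the data shown here, compound 3 therefore stands as the only compound of the three with an actual number in this assay; the other two sit at the limit described by the limit of > 200000 nM in this assay, at which 2 of the 3 values shown sit. The step to compound 4 `CNCCNc1c(F)cc2c(=O)c(C(=O)O)cn(Cc3ccc(-c4ccccc4)cc3)c2c1OC` is methylamino in place of (methylamino)methyl on a saturated chain carbon, two bonds along the chain from a nitrogen on an aromatic ring. Among the measured compounds shown here, only one measured step exists, an at least 1.9-fold lower number from compound 1 to compound 3 (0.29 log units; that floor lies within the scatter), and it swaps a ring for a chain, so it bears on the new change only loosely; its floor lies within the scatter. Compound 2 carries the same (2-(methylamino)ethyl)amino chain that enters in compound 4 and reaches only a limit in this assay, but it differs from compound 4 in more than one place, so its value is noted without being read as a step. No shortening of this chain has been measured here. The expectation is that the shorter chain leaves the weak inhibition roughly where it is, with a drift toward the limit more likely than a gain. Compound 4 is expected to give 150000 nM in this assay, within 50000 nM to 400000 nM. That estimate corresponds to an expected step of a 1.5-fold higher number from compound 3 to compound 4 (0.17 log units; within the scatter).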

Compound 4, half-maximal inhibitory concentration: > 200000 nM
Compound 4 was reported as a limit (the forecaster's own chance of this, stated with the estimate: 50%); middle value at least 1.3-fold (0.12 log units) from the limit.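

In this assay, among these compounds, replacing (3-(methylamino)propyl)amino with (2-(methylamino)ethyl)amino gives an at least 1.9-fold higher number from compound 3 to compound 4 (0.29 log units; that floor lies within the scatter); this is the first measured change of chain length at this place on the shared core, and it brings no gain. Compound 4's value is a limit, so the real size of this step is hidden, and its printed floor does not go beyond the usual scatter of repeated measurements, which means the longer chain of compound 3 cannot yet be called better. The steps from compound 2 and from compound 1 to compound 4 cannot be read, as both ends are limits, and the series as shown mostly sits at the edge of what the assay can report: the limit of > 200000 nM in this assay, at which 3 of the 4 values shown sit.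

The compounds shown leave open whether a longer chain, such as (4-(methylamino)butyl)amino, would lower the number further than compound 3 does, which would turn a possible trend with chain length into a measured one. They also leave open whether the end of the chain matters, for instance a primary amine or a dimethylamino group in place of the methylamino group.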